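Fluoro for methoxy on the shared core

The source may hold more compounds than are shown below. What is called first, only, known or untested is meant among the compounds shown, and "the series" means these compounds.

Measured compounds in a functional assay on the whole organism with Rattus norvegicus as the target, at a dose of 20 mg/kg by the oral route; on this read-out lower numbers stand for less inhibition and higher numbers for more inhibition at the one dose given (going by the name of the read-out):
- compound 1 `NC(=O)/C=C1\CCc2cc(Cl)ccc21`: 29%
- compound 2 `NC(=O)/C=C1\CCc2cc(F)cc(F)c21`: 55%
- compound 3 `COc1ccc2c(c1)CC/C2=C\C(N)=O`: 25%

Compound 3 gives the lowest of the three numbers in this assay, but its nearest neighbour is compound 1, and the step of a number 4 percentage points lower from compound 1 to compound 3 (within the scatter) lies within the scatter, so the two cannot be ordered. Going by the values given here, compound 2 stands further away, its number being beyond the scatter above that of compound 3; no single-place step links compound 2 to the others, so only the two values themselves can be compared.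

Compound 4 `NC(=O)/C=C1\CCc2cc(F)ccc21` is not yet measured. It differs from compound 3 as follows: fluoro in place of methoxy on an aromatic carbon. Among the compounds with values here, the only measured step that bears on a change at this aromatic carbon is the one from chloro to methoxy, a number 4 percentage points lower from compound 1 to compound 3 (within the scatter), which was within the scatter. On that basis a step in this assay of no more than the scatter is expected, a number 8 percentage points higher from compound 3 to compound 4 (within the scatter), with compound 2 as the only hint that fluorine could push higher. Compound 4 is therefore estimated at 33%, in the range 15% to 55%.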

Compound 4, a percentage reported as inhibition, in the whole organism at one dose (the size of the read-out at that dose, not a potency): 42%
The estimate for compound 4 lay 9 percentage points below the measured number; the range from low to high includes it.
By their numbers in this assay, from the lowest: compounds 3 and 1 (each within the scatter of the next); then compound 4; then compound 2.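

In this assay the group on this aromatic carbon now makes a readable difference: a number 17 percentage points higher from compound 3 to compound 4 (beyond the scatter) and a number 13 percentage points higher from compound 1 to compound 4 (beyond the scatter) set fluoro apart from both methoxy and chloro, whereas the earlier step between those two groups stayed within the scatter. The change of fluoro to hydrogen on an aromatic carbon also registers, as a number 13 percentage points lower from compound 2 to compound 4 (beyond the scatter) shows, so the fluoro at this place does not account for the whole of the highest number in the series. Nothing available explains why these groups differ in this way.

The compounds shown leave open how a nitrile, a trifluoromethyl or an amine at this aromatic carbon would compare with fluoro. They also leave open how the shared core would read with plain hydrogen at this place.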